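Methyl to Methoxy on the Aromatic Ring: Compound 2 to Compound 3

This account rests on a few compounds, and the source may have more. Where it says the series, first, only, none or still open, it means among the compounds named here.

Measured compounds:
compound 1 `COC(=O)[C@@]1(C)CCC=C2[C@@H]1CC[C@@H](C)[C@]2(C)Cc1c[nH]c2ccc(Br)cc12` gives 20000 nM
compound 2 `COC(=O)[C@@]1(C)CC[C@@H]2C3=C1CC[C@@H](C)[C@]3(C)C[C@@H]1c3cc(C)ccc3N[C@H]21` gives 32000 nM

In a functional assay on WiDr cells (Homo sapiens) for inhibition, read by sulforhodamine B assay, with a stated time of 48 h (on this read-out higher numbers stand for weaker inhibition of growth and lower numbers for stronger inhibition of growth), compound 2 has the highest of the two numbers, and its nearest neighbour, compound 1, differs by an amount within the scatter, so the two values show no difference of order. Compound 3 `COC(=O)[C@@]1(C)CC[C@@H]2C3=C1CC[C@@H](C)[C@]3(C)C[C@@H]1c3cc(OC)ccc3N[C@H]21` differs from compound 2 by methoxy in place of methyl on an aromatic carbon. Among the measured compounds shown here, no measured pair shows this change, so no step size is known. Compound 3 is expected to stay close to compound 2, with a 1.1-fold lower number from compound 2 to compound 3 (0.03 log units; within the scatter) estimated as no change beyond the scatter. The estimate for compound 3 is 30000 nM, in the range 10000 nM to 90000 nM.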

Compound 3, concentration for 50% growth inhibition: 25000 nM
Compound 3: the middle estimate sits 1.2-fold (0.08 log units) above what was measured; the measured number falls inside the stated range.
By their numbers in this assay, from the lowest: compounds 1, 3 and 2 (each within the scatter of the next).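

In this assay, methoxy in place of methyl on this aromatic carbon gives a 1.3-fold lower number from compound 2 to compound 3 (0.11 log units; within the scatter) and so does not separate the two compounds. This position therefore carries either methyl or methoxy, the latter with its hydrogen-bond acceptor, without a change beyond the scatter. No supporting measurement bears on this result.

On these data alone, whether an amine or a carboxylic acid on the same carbon would shift the number beyond the scatter remains open. The compounds shown also leave open how a longer chain would behave there.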